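Thiophene in Place of Iodophenyl: Cytotoxicity Expectation

The source may report more compounds than this note shows. Statements on the series, on what has been measured and on what is new or still open speak of the compounds shown alone.

Compound 1 `O=C(/C=C/c1ccc2c(c1)B(O)OC2)c1ccc(I)cc1` is examined in an ADME assay on L929 cells (Mus musculus) for cytotoxicity, read by resazurin assay, with a stated time of 72 h; a lower number here means a stronger inhibitor, a higher number a weaker inhibitor. In this assay compound 1 gives only a limit, > 10 ug/mL. Compound 2 `CSc1ccc(C(=O)/C=C/c2ccc3c(c2)B(O)OC3)cc1` likewise gives only a limit in this assay, > 10 ug/mL. Compound 3 `CCOC(=O)c1ccc(C(=O)/C=C/c2ccc3c(c2)B(O)OC3)cc1` also gives only a limit in this assay, > 10 ug/mL. Because all three values sit at the limit of > 10 ug/mL in this assay, at which 3 of the 3 values shown sit, the steps a step that the two limits leave unreadable from compound 1 to compound 2, a step that the two limits leave unreadable from compound 1 to compound 3 and a step that the two limits leave unreadable from compound 2 to compound 3 cannot be read in size. Compound 4 `O=C(/C=C/c1ccc2c(c1)B(O)OC2)c1cccs1` differs from compound 1 in one place: thiophen-2-yl in place of 4-iodophenyl on a carbonyl carbon. Within the data shown here, no measured step bears on this change, and the limits give no size for it. Compound 4 is therefore expected to give 20 ug/mL in this assay, with a range from 8 ug/mL to 60 ug/mL. The expected step that the limit leaves unreadable from compound 1 to compound 4 is thus estimated as none beyond the scatter.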

Compound 4, half-maximal inhibitory concentration: > 10 ug/mL
Compound 4: only a limit was reported; the forecaster's own chance of this, stated with the estimate: 80%; the middle value does not contradict the limit.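

Compound 1 and compound 4 both give only a limit, so no step between them can be read: the limit of > 10 ug/mL in this assay, at which 4 of the 4 values shown sit.

The compounds shown leave open what half-maximal inhibitory concentration any of them has, and whether thiophen-2-yl in place of 4-iodophenyl changes it at all.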